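This account rests on a few compounds, and the source may have more. Where it says the series, first, only, none or still open, it means among the compounds named here.

Compound 1 `O=C(N/N=C(/c1ccccc1)c1ccc(O)cc1)Nc1nnc(COc2ccc3ccccc3c2)o1` and compound 2 `CN(C)c1ccc(/C=N\NC(=O)Nc2nnc(COc3ccc4ccccc4c3)o2)cc1` share the same core and differ only in the group hung from the hydrazone end. In a functional assay on the whole organism (strain Swiss albino) with Mus musculus as the target, in the maximal electroshock model, with a stated time of 0.5 h (on this read-out higher numbers stand for an effect only at larger amounts of compound and lower numbers for an effect already at smaller amounts), compound 1 gives 100 mg/kg. In the same assay compound 2 gives 100 mg/kg. On these numbers compound 1 stands level with compound 2, and the two values lie within the usual scatter of each other.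

Compound 3 `O=C(N/N=C(/c1ccccc1)c1ccc([N+](=O)[O-])cc1)Nc1nnc(COc2ccc3ccccc3c2)o1` is compound 1 with one change: nitro in place of hydroxy on an aromatic carbon. Among the compounds with values here, no measured pair in this set carries that change, so nothing here shows how large a step it brings. With two compounds of the same core sitting at the same dose, the expected step of no change at the digits printed from compound 1 to compound 3 (within the scatter) in this assay is none beyond the scatter. Compound 3 is therefore estimated at 100 mg/kg, with a likely range from 30 mg/kg to 300 mg/kg.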

Compound 3, minimum effective dose: 100 mg/kg
Beside the measured number, compound 3's estimate shows no gap at the digits printed; the range from low to high includes it.
By their numbers in this assay, from the lowest: compounds 1, 2 and 3 (each within the scatter of the next).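

Compounds 1 and 2 differ in more than one place, so they could not show what a single change at this position does. The pair now gives that reading: in this assay, going from 4-hydroxyphenyl to 4-nitrophenyl, on an aromatic carbon para to a large group, brings no change at the digits printed from compound 1 to compound 3 (within the scatter) even though the nitro has no hydrogen-bond donor and more heavy atoms than the hydroxy, so in this pair the donor is not needed to hold the value. Nothing available explains why the value holds.

Going by these compounds, whether an amine, a carboxylic acid or a methoxy group at this same place would move the value beyond the scatter remains open. So does the effect of changing the naphthyloxymethyl side of the shared core while keeping the 4-nitrophenyl group.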